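Swapping an Alkyne for a Cyclopropyl Ring on the Amide

The source may hold more compounds than are shown below. What is called first, only, known or untested is meant among the compounds shown, and "the series" means these compounds.

Two measured compounds open this series. For the measured compounds named here, compound 1 `C/C=C/C(=O)N(Cc1ccc(OC)c(N)c1)c1cc(OC)c(OC)c(OC)c1` and compound 2 `C#CC(=O)N(Cc1ccc(OC)c(O)c1)c1cc(OC)c(OC)c(OC)c1` share the same core but differ in more than one place, so no single step connects them. In a functional assay on MGC-803 cells (Homo sapiens) for inhibition, read by MTT assay, with a stated time of 48 h (a lower number here means a stronger inhibitor, a higher number a weaker inhibitor), compound 1 gives 150 nM. In this assay compound 2 gives 170 nM; this is the higher of the two numbers, yet the gap to compound 1 lies within the usual scatter of repeated measurements, so the two compounds cannot be told apart on these data.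

Compound 2 is the starting point for compound 3 `COc1ccc(CN(C(=O)C2CC2)c2cc(OC)c(OC)c(OC)c2)cc1O`, which has not yet been measured. The change between them is cyclopropyl in place of ethynyl on a carbonyl carbon. Cut one bond further out, the same difference reads ethynylcarbonyl to cyclopropylcarbonyl.

Going by the values given here, no measured pair shows this change, so the expectation rests on compound 2 alone. In this assay the step is estimated as a 1.5-fold higher number from compound 2 to compound 3 (0.18 log units; within the scatter), a small rise that may well stay inside the scatter. Compound 3 is therefore expected to give about 260 nM, with a range from 110 nM to 700 nM.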

Compound 3, half-maximal inhibitory concentration: 59 nM
Beside the measured number, compound 3's estimate is 4.4-fold (0.64 log units) above it, and the stated range ends above it.
By their numbers in this assay, from the lowest: compound 3; then compounds 1 and 2 (each within the scatter of the next).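

For the compounds shown here, the group on the carbonyl carbon of this amide clearly matters: cyclopropyl in place of ethynyl gives a 2.9-fold lower number from compound 2 to compound 3 (0.46 log units; beyond the scatter) in this assay, a modest change but one beyond the scatter, and the first step that can be read from a single change. Neither group has a hydrogen-bond donor or acceptor, and the swap exchanges a triple bond outside any ring for a three-membered ring of carbon only, so a stronger result at this place does not require adding either kind of hydrogen-bonding feature. Nothing available on these compounds accounts for the lower number, so the reason for the step remains unknown.

This single pair cannot show whether the ring itself, its size, or simply the loss of the triple bond drives the change, and a cyclobutyl ring, an open ethyl or longer chain, or an amine on the same carbonyl carbon would help to separate these possibilities. It also leaves open whether the same swap would have a similar effect on a compound carrying the amine of compound 1 in place of the hydroxyl group of compound 2.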